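A few compounds are considered here, and "the series" means these few. Any claim that something is new, unique, unknown or untested is made for them only; others in the source may bear on it.

Two members of the series share one core and differ only in the aryl group on the amide-type nitrogen. Compound 1 `Cc1occc1-c1nnc(SCC(=O)Nc2ccc(F)c(Cl)c2)n1Cc1ccco1` gives 39.8 nM in a functional assay on CHO cells for antagonist activity at Orexin receptor type 2 (Homo sapiens), read by FLIPR and calcium flux (a higher number here means a weaker inhibitor, a lower number a stronger inhibitor), and compound 2 `Cc1cccc(NC(=O)CSc2nnc(-c3ccoc3C)n2Cc2ccco2)c1` gives 50.1 nM in this assay. The step of a 1.3-fold higher number from compound 1 to compound 2 (0.10 log units; within the scatter) shows that this aryl exchange left the number essentially where it was. Within the data shown here, on the two numbers so far, compound 2 stands highest, with compound 1 nearest and within the scatter of it.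

Compound 3 `COc1ccccc1NC(=O)CSc1nnc(-c2ccoc2C)n1Cc1ccco1` is the next variation at the same place: 2-methoxyphenyl in place of 3-methylphenyl on an amide-type nitrogen. Among the measured compounds shown here, the only measured step that bears on it is a 1.3-fold higher number from compound 1 to compound 2 (0.10 log units; within the scatter), an aryl exchange on the same nitrogen that moved nothing beyond the scatter. For compound 3 the step of a 1.0-fold lower number from compound 2 to compound 3 (0.00 log units; within the scatter) is therefore expected to stay inside the scatter, with no direction favoured. Compound 3 is estimated at 50 nM in this assay, with a range from 18 nM to 140 nM.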

Compound 3, inhibition constant: 501 nM
The estimate for compound 3 lay 10-fold (1.00 log units) below the measured number; measured number outside the range, above it.
By their numbers in this assay, from the lowest: compounds 1 and 2 (each within the scatter of the next); then compound 3.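

The aryl group on the amide-type nitrogen is not a freely exchangeable place in this assay: a 10-fold higher number from compound 2 to compound 3 (1.00 log units; beyond the scatter), and a 13-fold higher number from compound 1 to compound 3 (1.10 log units; beyond the scatter), whereas the earlier exchange at this nitrogen stayed within the scatter. Of the three aryl groups, 2-methoxyphenyl alone separates from the others, so this place accepts 3-chloro-4-fluorophenyl and 3-methylphenyl alike but not every aryl group. Nothing available explains why this exchange raises the number.

The step from 3-methylphenyl to 2-methoxyphenyl changes both the group on the ring and where it sits, and the compounds shown do not separate these two changes. A 3-methoxyphenyl or a 2-methylphenyl group on the same nitrogen would bear on that question, and a 2-hydroxyphenyl group would bear on the role of the methoxy methyl.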